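A few compounds are considered here, and "the series" means these few. Any claim that something is new, unique, unknown or untested is made for them only; others in the source may bear on it.

In a functional assay on 786-0 cells (Homo sapiens) for inhibition, read by sulforhodamine B assay, with a stated time of 48 h (on this read-out lower numbers stand for stronger inhibition of growth and higher numbers for weaker inhibition of growth), compound 1 (`CCOC(=O)C1=C(C)NC(=O)NC1c1ccc(SC)cc1`) gives 2.5 ug/mL and stands apart from the other two measured compounds. Compound 3 (`CCCc1ccc(C2NC(=O)NC(C)=C2C(=O)OCC)cc1`) gives 18.8 ug/mL and lies within the scatter of compound 2 (`CCOC(=O)C1=C(C)NC(=O)NC1c1ccc(O)c(O)c1`), which gives 25.7 ug/mL in the same test. Compound 3 therefore sits with compound 2 and well away from compound 1.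

The next change leads to compound 4 (`CCOC(=O)C1=C(C)NC(=O)NC1c1ccc(O)cc1`): hydroxy in place of propyl on an aromatic carbon, para to a large group (hydroxy in place of propyl on an aromatic carbon).

For the measured compounds named here, only one measured step bears on this place: a 7.5-fold higher number from compound 1 to compound 3 (0.88 log units; beyond the scatter) with propyl in place of methylsulfanyl on an aromatic carbon. It shows that exchanging the group here can move the number beyond the scatter, but it says nothing directly about hydroxy. Going by the values given here, the closest evidence is compound 2 at 25.7 ug/mL in this assay, the only measured compound with hydroxy on the aromatic ring. It differs from compound 4 by a further hydroxy, so the comparison is indirect. Its value still points to no large move.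

The expected result is a 1.2-fold higher number from compound 3 to compound 4 (0.07 log units; within the scatter) and no step beyond the scatter is anticipated. For compound 4 the estimate is 22 ug/mL with an expected range of 8 ug/mL to 60 ug/mL.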

Compound 4, concentration for 50% growth inhibition: 25.8 ug/mL
The estimate for compound 4 lay 1.2-fold (0.07 log units) below the measured number; low and high end bracket the measured number.
By their numbers in this assay, from the lowest: compound 1; then compounds 3, 2 and 4 (each within the scatter of the next).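

In this assay, the exchange on an aromatic carbon para to a large group gives a 1.4-fold higher number from compound 3 to compound 4 (0.14 log units; within the scatter), so propyl, with 3 heavy atoms and no hydrogen-bond donor, and hydroxy, with 1 heavy atom and 1 hydrogen-bond donor, are not told apart at this position. The further hydroxy on the ring also leaves the reading within the scatter, at a 1.0-fold higher number from compound 2 to compound 4 (0.00 log units; within the scatter), whereas a 10-fold higher number from compound 1 to compound 4 (1.01 log units; beyond the scatter) adds a second step beyond the scatter, so methylsulfanyl now stands apart from both propyl and hydroxy. No measurement at hand offers a reason for the gap between methylsulfanyl and these two groups.

Still open, from the compounds shown here alone, is whether the separate reading of methylsulfanyl depends on its sulfur atom or on the group as a whole, a question that methoxy or ethylsulfanyl at the same place would address. Also open, going by these compounds, is whether an amine, a carboxylic acid or a longer chain than propyl would stay with hydroxy and propyl or move toward methylsulfanyl on this read-out.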